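The source may report more compounds than this note shows. Statements on the series, on what has been measured and on what is new or still open speak of the compounds shown alone.

Compound 1 `N#CC1=C(N)Oc2c(N)cc3nc4ccccc4nc3c2C12C(=O)N(Cc1cnnn1-c1ccc(F)cc1)c1ccccc12`: in a functional assay on HCT-116 cells (Homo sapiens) for antiproliferative activity, read by MTT assay, with a stated time of 48 h (a higher number here means a weaker inhibitor, a lower number a stronger inhibitor), compound 1 gives > 50000 nM, which is a limit of the assay and not a number.
Compound 2 `N#CC1=C(N)Oc2c(N)cc3nc4ccccc4nc3c2C12C(=O)N(Cc1cnnn1-c1ccccc1Cl)c1ccccc12`: in this assay compound 2 gives > 50000 nM, again a limit rather than a number.
Compound 3 `Cc1ccc(Cl)cc1-n1nncc1CN1C(=O)C2(C(C#N)=C(N)Oc3c(N)cc4nc5ccccc5nc4c32)c2ccccc21`: in this assay compound 3 gives 37200 nM.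

Compound 3 is thus the only one of the three with a measured number; the other two sit at the limit of > 50000 nM in this assay, at which 2 of the 3 values shown sit. The two steps that end at compound 3 are an at least 1.3-fold lower number from compound 1 to compound 3 (0.12 log units; that floor lies within the scatter) and an at least 1.3-fold lower number from compound 2 to compound 3 (0.12 log units; that floor lies within the scatter), and both are only floors that fall within the scatter. The step that the two limits leave unreadable from compound 1 to compound 2 cannot be read at all. Compound 4 `N#CC1=C(N)Oc2c(N)cc3nc4ccccc4nc3c2C12C(=O)N(Cc1cnnn1-c1ccc(F)c(Cl)c1)c1ccccc12` differs from compound 3 by 3-chloro-4-fluorophenyl in place of 5-chloro-2-methylphenyl on an aromatic nitrogen. The new ring carries a fluorine, as the ring of compound 1 does, and a chlorine, as the rings of compound 2 and compound 3 do, so all three measured compounds bear on it, and none of them shows a step beyond the scatter. For compound 4 the expected step is therefore a 1.2-fold higher number from compound 3 to compound 4 (0.08 log units; within the scatter), that is, no change beyond the scatter. Compound 4 is accordingly estimated at 45000 nM in this assay, with a range from 20000 nM to 100000 nM, and a fair chance that only a limit is reported.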

Compound 4, half-maximal inhibitory concentration: > 50000 nM
Compound 4: only a limit was reported; the forecaster's own chance of this, stated with the estimate: 40%; middle value at least 1.1-fold (0.04 log units) away from the limit.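

With 3-chloro-4-fluorophenyl on the aromatic nitrogen, compound 4 also ends in a limit of the assay rather than a number, so putting chlorine and fluorine on one ring does not bring a measurable value in this assay. Among the compounds shown here, the only step that can be read, an at least 1.3-fold higher number from compound 3 to compound 4 (0.12 log units; that floor lies within the scatter), is a floor, so it does not show that replacing 5-chloro-2-methylphenyl with this ring truly changes the result, and the steps among compound 1, compound 2 and compound 4 cannot be read because each has a limit at both ends. Compound 3 remains the only compound with a number, and the series now gathers at a single boundary: the limit of > 50000 nM in this assay, at which 3 of the 4 values shown sit.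

As far as these compounds go, the true values behind the limits remain open, and so does whether the methyl group on the ring of compound 3 has any part in its measured number. From the compounds shown here alone, it is also open whether a ring carrying a methoxy group, an amine or a carboxylic acid at this place would give a clearly lower number than compound 3 does.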